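The source may report more compounds than this note shows. Statements on the series, on what has been measured and on what is new or still open speak of the compounds shown alone.

In an assay on HEK293 cells for positive allosteric modulation of metabotropic glutamate receptor 5 (Homo sapiens), read by FLIPR, with a stated time of 1 h (a lower number here means that less compound is needed, a higher number that more compound is needed for the effect), three compounds sharing one core have been measured so far. Compound 1 `CC(C)CN1CCc2nc(C#Cc3ccccc3)sc2C1` carries an isobutyl group on the ring amine nitrogen, and in this assay its value is only a limit, > 10000 nM. Compound 2 `O=C(C1CCCO1)N1CCc2nc(C#Cc3ccccc3)sc2C1` carries (oxolan-2-yl)carbonyl in that place instead and gives 790 nM, which is an at least 12-fold lower number from compound 1 to compound 2 (1.10 log units; beyond the scatter). Compound 3 `CC1CCCC(C(=O)N2CCc3nc(C#Cc4ccccc4)sc3C2)C1` carries 3-methylcyclohexyl on the carbonyl carbon and gives 100 nM, a further step of a 7.9-fold lower number from compound 2 to compound 3 (0.90 log units; beyond the scatter). Going by the values given here, of the two numbers known, compound 3 therefore stands lowest, with compound 2 as its nearest neighbour.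

Compound 4 `O=C(N1CCCCC1)N1CCc2nc(C#Cc3ccccc3)sc2C1` has not yet been measured. It differs from compound 3 in one place: piperidin-1-yl in place of 3-methylcyclohexyl on a carbonyl carbon. Among the compounds with values here, the measured step that bears on this is the one from compound 2 to compound 3, where a carbon-only ring in place of a ring with one hetero atom brought a modest lowering of the number; in compound 4 a ring with one hetero atom enters again, though joined through its nitrogen. A modest rise, smaller than that earlier step, is therefore expected. Compound 4 is estimated at 250 nM, with a range from 80 nM to 800 nM. That estimate means an expected step of a 2.5-fold higher number from compound 3 to compound 4 (0.40 log units; beyond the scatter).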

Compound 4, half-maximal effective concentration: 75 nM
For compound 4 the middle estimate is 3.3-fold (0.52 log units) above the measured one; measured number outside the range, below it.
By their numbers in this assay, from the lowest: compounds 4 and 3 (each within the scatter of the next); then compound 2. At a limit, above all of these: compound 1.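

In this assay, piperidin-1-yl in place of 3-methylcyclohexyl on a carbonyl carbon gives a 1.3-fold lower number from compound 3 to compound 4 (0.12 log units; within the scatter), so at this place the two six-membered rings cannot be told apart, although one holds a nitrogen and the other is of carbon only. Oxolan-2-yl also brings a ring with one hetero atom, yet piperidin-1-yl in its place gives an 11-fold lower number from compound 2 to compound 4 (1.02 log units; beyond the scatter), which shows that a carbon-only ring is not needed for a number in the range of compound 3, and that a hetero atom in the ring does not by itself go with a higher number. The step of an at least 130-fold lower number from compound 1 to compound 4 (2.12 log units; beyond the scatter) rests on the limit of compound 1, which is a limit and not a number: the limit of > 10000 nM in this assay, at which 1 of the 4 values shown sits.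

The compounds shown leave open whether a plain cyclohexyl or a 4-methylpiperidin-1-yl on the same carbonyl carbon would stay within the scatter of compound 3 and compound 4, and so what the methyl group contributes. Also open, as far as these compounds go, is how a morpholin-4-yl group, with a second hetero atom in the ring, or an open-chain diethylamino group would read in this assay.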